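This account rests on a few compounds, and the source may have more. Where it says the series, first, only, none or still open, it means among the compounds named here.

Measured compounds:
- compound 1, `N#Cc1cccc(Nc2ncnc3cc(NC(=O)/C=C/c4ccccc4)sc23)c1`, 7220 nM
- compound 2, `COc1ccc(/C=C/C(=O)Nc2cc3ncnc(Nc4ccc(F)c(Cl)c4)c3s2)cc1`, 20600 nM
- compound 3, `O=C(/C=C/c1ccc(O)cc1)Nc1cc2c(Nc3ccc(Cl)c(Cl)c3)ncnc2s1`, 24800 nM

All three share one core and differ in the aniline and in the aryl group on the cinnamamide. In a functional assay on HeLa cells (Homo sapiens) for antiproliferative activity, read by MTT assay, with a stated time of 48 h (a lower number here means a stronger inhibitor, a higher number a weaker inhibitor), compound 1 gives 7220 nM, compound 2 gives 20600 nM and compound 3 gives 24800 nM. Compound 3 stands at the highest of the three numbers. Its nearest neighbour is compound 2, whose number lies within the scatter of it, so no order between compound 2 and compound 3 is read. Compound 1 gives a lower number, a gap beyond the scatter, and is therefore the only one of the three that is set apart.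

Compound 4, `COc1ccc(/C=C/C(=O)Nc2cc3c(Nc4ccc(Cl)c(Cl)c4)ncnc3s2)cc1`, has not been measured in this assay. It differs from compound 3 in one place:

methyl in place of hydrogen on an oxygen on an aromatic ring

Going by the values given here, no measured pair in this set differs by this change alone, so its size is not known from these data. Compound 2 carries the methoxy group already, with a different aniline, and gives a number within the scatter of compound 3. The expected step from compound 3 to compound 4 in this assay, a 1.2-fold lower number from compound 3 to compound 4 (0.09 log units; within the scatter), is small, towards a slightly lower number, and within the scatter. Compound 4 is estimated at 20000 nM, with a range of 8000 nM to 50000 nM.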

Compound 4, half-maximal inhibitory concentration: 33 nM
Beside the measured number, compound 4's estimate is 610-fold (2.78 log units) above it, and the stated range ends above it.
By their numbers in this assay, from the lowest: compound 4; then compound 1; then compounds 2 and 3 (each within the scatter of the next).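

In this assay, going by these compounds alone, replacing hydroxy with methoxy on the 4-hydroxyphenyl group gives a 750-fold lower number from compound 3 to compound 4 (2.88 log units; beyond the scatter), a large step and the first reading of a change at this position on its own. The earlier compounds shown here differed in more than one place, so they could assign nothing to the group on this oxygen, whereas this pair shows that one methyl, a single carbon with no ring and no net charge, separates a weak compound from a strong one on this aniline and core. Nothing measured here bears on why a change this small produces a step this large.

From the compounds shown here alone, it remains open whether the step belongs to methyl specifically, or whether a longer chain such as ethoxy, or an amine or a carboxylic acid in place of the methoxy group, would give a low number as well. Going by these compounds, it also remains open whether the same change gives a step of similar size with the anilines of compound 1 and compound 2, since this single pair speaks for the 3,4-dichloroaniline series only.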